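Adding a Methoxy to the Fused Ring of Compound 3

A few compounds are considered here, and "the series" means these few. Any claim that something is new, unique, unknown or untested is made for them only; others in the source may bear on it.

Compound 1 `COc1ccc2nc(NC(=O)c3cn(-c4ccccc4)nc3-c3ccc(F)cc3)sc2c1`: 12800 nM
Compound 2 `O=C(Nc1nc2ccccc2s1)c1cn(-c2ccccc2)nc1-c1ccc(Cl)cc1`: 7750 nM
Compound 3 `COc1ccc(-c2nn(-c3ccccc3)cc2C(=O)Nc2nc3ccccc3s2)cc1`: 6670 nM

In a functional assay on PC-3 cells (Homo sapiens) for cytotoxicity, read by MTT assay, with a stated time of 72 h (on this read-out higher numbers stand for weaker inhibition and lower numbers for stronger inhibition), compound 3 sits among three numbers that all lie within the scatter of one another; the nearest is compound 2, the furthest compound 1. Compound 4 `COc1ccc(-c2nn(-c3ccccc3)cc2C(=O)Nc2nc3ccc(OC)cc3s2)cc1` differs from compound 3 by methoxy in place of hydrogen on an aromatic carbon. Within the data shown here, no measured step covers exactly this change. Among the measured compounds shown here, the only measured step, a 1.2-fold lower number from compound 2 to compound 3 (0.07 log units; within the scatter), concerns a different ring. Compound 1 carries the same methoxy on the fused ring, but together with a different halogen, and its number stays within the scatter of compound 2. A step of a 1.1-fold higher number from compound 3 to compound 4 (0.05 log units; within the scatter) is therefore expected, none beyond the scatter. For compound 4 the estimate is 7500 nM, within a range from 3000 nM to 18000 nM.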

Compound 4, half-maximal inhibitory concentration: 13500 nM
The estimate for compound 4 lay 1.8-fold (0.26 log units) below the measured number; the range from low to high includes it.
By their numbers in this assay, from the lowest: compounds 3, 2, 1 and 4 (each within the scatter of the next, the first and the last beyond it).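

Placing a methoxy on the fused ring, as the change from 1,3-benzothiazol-2-yl to 6-methoxy-1,3-benzothiazol-2-yl, gives in this assay a first step beyond the scatter (a 2.0-fold higher number from compound 3 to compound 4 (0.31 log units; beyond the scatter)), so this position does respond to substitution, if only modestly. With that methoxy present, fluoro and methoxy on the other ring cannot be told apart (a 1.1-fold higher number from compound 1 to compound 4 (0.02 log units; within the scatter)). Nothing available explains the step. From the compounds shown here alone, whether a hydroxyl, an amine or a longer chain such as ethoxy at this position would give a similar number stays open.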